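Swapping the Alkyne Aryl: Pyridine to Plain Phenyl

The compounds below may be only part of what the source reports. "The series", "measured", "known", "first", "only" and "open" are said of these compounds alone.

Compound 1 `COC(=O)c1sc2cc(C#Cc3ccc(N)cc3)cnc2c1N`: 4800 nM
Compound 2 `COC(=O)c1sc2cc(C#Cc3cccnc3)cnc2c1N`: > 150000 nM, a limit of the assay

In a functional assay on A375-C5 cells (Homo sapiens) for inhibition, read by sulforhodamine B assay, with a stated time of 48 h (on this read-out lower numbers stand for stronger inhibition of growth and higher numbers for weaker inhibition of growth), compound 1 gives 4800 nM. For compound 2 this assay reports only a limit, > 150000 nM. Compound 2 therefore sits at the limit of > 150000 nM in this assay, at which 1 of the 2 values shown sits, the weaker of the two results shown. Compound 3 `COC(=O)c1sc2cc(C#Cc3ccccc3)cnc2c1N` carries phenyl in place of pyridin-3-yl on a triple-bonded carbon. Going by the values given here, the one measured step that touches this position, an at least 31-fold higher number from compound 1 to compound 2 (1.49 log units; beyond the scatter), was large and came with both the loss of an amino group and the arrival of a ring nitrogen. Going to compound 3 removes only the ring nitrogen, so a partial recovery is expected, an at least 5.0-fold lower number from compound 2 to compound 3 (0.69 log units; beyond the scatter). Compound 3 is expected near 30000 nM, within 6000 nM to 150000 nM.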

Compound 3, concentration for 50% growth inhibition: > 150000 nM
Compound 3 was reported as a limit (the forecaster's own chance of this, stated with the estimate: 35%); middle value at least 5.0-fold (0.69 log units) from the limit.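

Compound 3 is reported only as a limit, > 150000 nM. Compound 2 is also a limit, so the step between these two compounds cannot be read, and taking out the ring nitrogen gave no readable recovery. The comparison with compound 1 now rests on one change, hydrogen in place of amino on an aromatic carbon, and shows an at least 31-fold higher number from compound 1 to compound 3 (1.49 log units; beyond the scatter), so this single change is enough for a large loss; compound 3 joins compound 2 at the same limit: the limit of > 150000 nM in this assay, at which 2 of the 3 values shown sit.

From the compounds shown here alone, how far compound 2 and compound 3 lie past that limit stays open. So does whether a hydroxyl or a dimethylamino group on that aromatic carbon would retain the growth inhibition seen with compound 1.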